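The source may hold more compounds than are shown below. What is called first, only, known or untested is meant among the compounds shown, and "the series" means these compounds.

Of the compounds shown here, three have so far been tested in a functional assay on HCT-116 cells (Homo sapiens) for cytotoxicity, read by MTT assay, with a stated time of 48 h; on this read-out higher numbers stand for weaker inhibition and lower numbers for stronger inhibition. Compound 1 `O=C(CC1c2ccccc2N=C(SCCCCCN2CCCC2)N1c1ccc(-c2ccccc2)cc1)NCc1ccc(F)cc1` gives 6200 nM in this assay. Compound 3 `O=C(CC1c2ccccc2N=C(SCCCCCN2CCCC2)N1c1ccc(-c2ccccc2)cc1)NCc1ccccc1` differs from compound 1 only by hydrogen in place of fluoro on an aromatic carbon, and in this assay compound 3 gives 5500 nM; the step is a 1.1-fold lower number from compound 1 to compound 3 (0.05 log units; within the scatter). Compound 2 `CN(C)CCCCCSC1=Nc2ccccc2C(CC(=O)NCc2ccc(F)cc2)N1c1ccccc1` is built on a different core, and how the core of compound 2 differs from that of compound 1 is not broken down here. In this assay compound 2 gives 38800 nM, the highest of the three numbers and beyond the scatter from both of the others.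

Compound 4 `CN(C)CCCCCSC1=Nc2ccccc2C(CC(=O)NCc2ccccc2)N1c1ccccc1` has not been measured. It differs from compound 2 by hydrogen in place of fluoro on an aromatic carbon, the same change, at the same place, as that between compound 1 and compound 3. Because the measured step of a 1.1-fold lower number from compound 1 to compound 3 (0.05 log units; within the scatter) lies within the scatter, an equally small step is expected for compound 4, namely a 1.1-fold lower number from compound 2 to compound 4 (0.03 log units; within the scatter). In this assay compound 4 is therefore estimated at 36000 nM, with a likely range from 15000 nM to 90000 nM.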

Compound 4, half-maximal inhibitory concentration: 38800 nM
For compound 4 the middle estimate is 1.1-fold (0.03 log units) below the measured one, and the stated range covers the measured number.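

In this assay, hydrogen in place of fluoro on the aromatic carbon gives no change at the digits printed from compound 2 to compound 4 (within the scatter). Set beside the earlier step, the same change reads alike on the two cores: the same change on two cores in this assay, a 1.1-fold lower number (0.05 log units; within the scatter) from compound 1 to compound 3 and no change at the digits printed (within the scatter) from compound 2 to compound 4, 1.1-fold (0.05 log units) apart, within the scatter of two such steps

This shows that, on these two cores, the 4-fluorobenzyl and benzyl amides cannot be told apart in this read-out, and that the absence of a measurable step carries over from the core of compound 1 to the core of compound 2. It does not show that a change with a step beyond the scatter would carry over in the same way, and two cores say nothing about other cores in the series.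

The compounds shown leave open whether a larger group on the same aromatic carbon, such as methoxy or trifluoromethyl, would separate from fluoro and hydrogen in this assay. They also leave open what a longer chain between the amide nitrogen and the aromatic ring would do on either core.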